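The source may report more compounds than this note shows. Statements on the series, on what has been measured and on what is new or still open speak of the compounds shown alone.

Compound 1 `COc1ccc(N2C(=O)COc3ccc(-c4cnc(OC)c(NS(=O)(=O)c5ccc(F)cc5)c4)cc32)cc1` gives 13400 nM in a functional assay on HCT-116 cells (Homo sapiens) for antiproliferative activity, read by MTT assay, with a stated time of 72 h; a higher number here means a weaker inhibitor, a lower number a stronger inhibitor. Compound 2 `COc1cccc(N2C(=O)COc3ccc(-c4ccc(O)cc4)cc32)c1` gives 15300 nM in this assay. Compound 3 `COc1ccc(N2C(=O)COc3ccc(-c4cnc(Cl)c(NS(=O)(=O)c5ccc(F)cc5)c4)cc32)cc1` gives 30100 nM in this assay.

Compound 1 stands at the lowest of these three numbers, which in this assay means the strongest inhibitor of the set; its gap to compound 2 lies within the scatter, while the step of a 2.2-fold higher number from compound 1 to compound 3 (0.35 log units; beyond the scatter) lies beyond it. Compound 4 `COc1ncc(-c2ccc3c(c2)N(c2ccccc2)C(=O)CO3)cc1NS(=O)(=O)c1ccc(F)cc1` differs from compound 1 in one place: hydrogen in place of methoxy on an aromatic carbon. Within the data shown here, the single measured step, a 2.2-fold higher number from compound 1 to compound 3 (0.35 log units; beyond the scatter), concerns another ring and another exchange, so it bears only loosely on this change, and no measured pair isolates the loss of this methoxy. The expectation is thus a small step, probably none beyond the scatter. Compound 4 is estimated at 15000 nM (range 6000 nM to 40000 nM), an expected 1.1-fold higher number from compound 1 to compound 4 (0.05 log units; within the scatter).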

Compound 4, half-maximal inhibitory concentration: 18800 nM
For compound 4 the middle estimate is 1.3-fold (0.10 log units) below the measured one; measured number inside the range.
By their numbers in this assay, from the lowest: compounds 1, 2, 4 and 3 (each within the scatter of the next, the first and the last beyond it).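

In this assay, putting hydrogen in place of the methoxy on the 4-methoxyphenyl group gives a 1.4-fold higher number from compound 1 to compound 4 (0.15 log units; within the scatter) and so stays within the scatter. Among these compounds, this is the first measured pair that changes this position, and it shows that the methoxy can go without a clear loss of activity against these cells. Nothing available explains this result.

On these data alone, whether an amine or a longer chain such as butoxy at this place would shift the number beyond the scatter remains open. So does whether removing this methoxy would have the same small effect on a compound carrying chloro in place of methoxy on the other ring.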